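Furan-bearing core: from ethylamino acid toward a fluorobenzyl analogue

The source may hold more compounds than are shown below. What is called first, only, known or untested is meant among the compounds shown, and "the series" means these compounds.

Two compounds of this series have been examined in a functional assay on CHO cells for antagonist activity at adenosine receptor A2b (Homo sapiens) (a lower number here means a stronger inhibitor, a higher number a weaker inhibitor), so far. Compound 1, `CCOC(=O)c1cnc(N2CCCCC2)n2nc(-c3ccco3)nc12`, carries an ethyl ester and a piperidine on the shared core; in this assay compound 1 reaches only a limit, > 10000 nM. Compound 2, `CCNc1ncc(C(=O)O)c2nc(-c3ccco3)nn12`, carries a free carboxylic acid and an ethylamino group; in this assay compound 2 likewise reaches only a limit, > 10000 nM. Going by the values given here, both values therefore sit at the same boundary, (the limit of > 10000 nM in this assay, at which 2 of the 2 values shown sit), and no step between them can be sized.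

Compound 3, `O=C(O)c1cnc(NCc2ccc(F)cc2)n2nc(-c3ccco3)nc12`, is not yet measured. It differs from compound 2 by 4-fluorophenyl in place of methyl on a saturated chain carbon bound to a nitrogen on an aromatic ring, or, read one bond further out, ethyl to 4-fluorobenzyl. With compound 2 known only as a limit, the step from it cannot be anchored in a measured number; the author expects compound 3 to gain some potency, a step of an at least 3.3-fold lower number from compound 2 to compound 3 (0.52 log units; beyond the scatter), while allowing that it may again stop at the boundary. The estimate for compound 3 in this assay is 3000 nM, with a range from 500 nM to 10000 nM.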

Compound 3, inhibition constant: > 30000 nM
Compound 3: a limit, no number; the forecaster's own chance of this, stated with the estimate: 45%; middle value at least 10-fold (1.00 log units) from the limit.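

In this assay compound 2 and compound 3 each give only a limit and no number, so the step from ethyl to 4-fluorobenzyl cannot be read. The compounds shown leave open how far each lies past its limit, and whether any change on the shared core yields a measurable inhibition constant.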